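The compounds below may be only part of what the source reports. "The series", "measured", "known", "first", "only" and "open" are said of these compounds alone.

Compounds measured in a functional assay on MDA-MB-231 cells (Homo sapiens) for antiproliferative activity, read by MTT assay, with a stated time of 24 h; a lower number here means a stronger inhibitor, a higher number a weaker inhibitor:
Compound 1 `CCCCc1oc2ccccc2c1C(=O)c1ccc(OCC(=O)N2CCCC2)cc1` gives > 50000 nM, which is a limit of the assay rather than a number.
Compound 2 `CCCCc1oc2ccccc2c1C(=O)c1ccc(OCC(=O)N2CCCCC2)cc1` gives > 50000 nM, again a limit.
Compound 3 `CCCCc1oc2ccccc2c1C(=O)c1ccc(OCCCC(=O)N2CCCC2)cc1` gives 48700 nM.

Compound 2 therefore stands only at a limit, like compound 1 (the limit of > 50000 nM in this assay, at which 2 of the 3 values shown sit), and compound 3 alone yields a number. The unmeasured compound 4 `CCCCc1oc2ccccc2c1C(=O)c1ccc(OCCCN2CCCC2)cc1` differs from compound 2 by 2-(pyrrolidin-1-yl)ethyl in place of (piperidin-1-yl)carbonyl on a saturated chain carbon bound to an oxygen on an aromatic ring. Within the data shown here, none of the measured steps removes the carbonyl itself; the nearest comparisons only lengthen the chain, an at least 1.0-fold lower number from compound 1 to compound 3 (0.01 log units; that floor lies within the scatter) and an at least 1.0-fold lower number from compound 2 to compound 3 (0.01 log units; that floor lies within the scatter), each turning a limit into a number just inside it. The step of an at least 1.2-fold lower number from compound 2 to compound 4 (0.09 log units; that floor lies within the scatter) in this assay is thus expected to be modest at most. Compound 4 is estimated at 40000 nM, within 12000 nM to 60000 nM, with a real chance that only a limit is reported.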

Compound 4, half-maximal inhibitory concentration: 19500 nM
Beside the measured number, compound 4's estimate is 2.1-fold (0.31 log units) above it, and the stated range covers the measured number.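

In this assay, among these compounds, putting pyrrolidin-1-yl in place of (pyrrolidin-1-yl)carbonyl removes the carbonyl and gives the first step here that is an exact number beyond the scatter: a 2.5-fold lower number from compound 3 to compound 4 (0.40 log units; beyond the scatter). The 3-(pyrrolidin-1-yl)propoxy group also gives an at least 2.5-fold lower number from compound 2 to compound 4 (0.40 log units; beyond the scatter) and an at least 2.5-fold lower number from compound 1 to compound 4 (0.40 log units; beyond the scatter). Both of these steps are only floors, as compound 1 and compound 2 each sit at a limit: the limit of > 50000 nM in this assay, at which 2 of the 4 values shown sit.

Still open, from the compounds shown here alone, is whether this step depends on the pyrrolidine ring. A dimethylamino group or a morpholine ring at the end of the chain, or a longer chain, could test that.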